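Phenyl for Dimethylisoxazole: Expected Effect on Cell Tolerance

The source may report more compounds than this note shows. Statements on the series, on what has been measured and on what is new or still open speak of the compounds shown alone.

Of the compounds shown here, two sharing one core have been tested in an ADME assay on A549 cells (Homo sapiens) for cytotoxicity, read by CellTiter-Glo; a higher number here means that more compound is tolerated, a lower number that less compound is tolerated. Compound 1, `COc1ccc(Cc2c(C)c3ccc(OCC(O)CN4CCC(C(N)=O)CC4)cc3oc2=O)c(Br)c1`, gives 44400 nM in this assay. Compound 2, `Cc1noc(C)c1-c1ccc(Cc2c(C)c3ccc(OCC(O)CN4CCC(C(N)=O)CC4)cc3oc2=O)cc1`, gives 36900 nM in this assay. Compound 2 holds the lowest of the two numbers, but its nearest neighbour, compound 1, sits at a distance that falls within the usual scatter, so the two cannot be told apart on this evidence.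

Compound 3, `Cc1c(Cc2ccc(-c3ccccc3)cc2)c(=O)oc2cc(OCC(O)CN3CCC(C(N)=O)CC3)ccc12`, has not yet been measured. It differs from compound 2 in one place: phenyl in place of 3,5-dimethyl-1,2-oxazol-4-yl on an aromatic carbon. Among the compounds with values here, no measured pair shows a step of this kind, so the data give no direct guide. Compound 1 and compound 2 carry different groups on this ring yet give numbers within the scatter of each other, which makes a change at the same place in compound 3 expected to move the number little. The expected step is a 1.1-fold lower number from compound 2 to compound 3 (0.02 log units; within the scatter), no step beyond the scatter. Compound 3 is therefore estimated at 35000 nM, with a range from 15000 nM to 80000 nM.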

Compound 3, half-maximal cytotoxic concentration: > 100000 nM
Compound 3: only a limit was reported; the forecaster's own chance of this, stated with the estimate: 20%; middle value at least 2.8-fold (0.45 log units) from the limit.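

The reading for compound 3 in this assay is a limit of the assay and not a number: the limit of > 100000 nM in this assay, at which 1 of the 3 values shown sits. Even so, putting phenyl in place of 3,5-dimethyl-1,2-oxazol-4-yl gives an at least 2.7-fold higher number from compound 2 to compound 3 (0.43 log units; beyond the scatter), so a change at this aromatic carbon, para to a large group, can alter how much compound the cells tolerate, something compound 1 and compound 2, within the scatter of each other, did not reveal. As far as these compounds go, putting 4-phenylphenyl in place of 2-bromo-4-methoxyphenyl likewise gives an at least 2.2-fold higher number from compound 1 to compound 3 (0.35 log units; beyond the scatter), which sets compound 3 apart from both earlier compounds, although the true size of each step remains unknown.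

The compounds shown cannot separate the effect of having a ring of carbon only at this place from that of losing the two methyl groups and the ring's hetero atoms. A pyridine ring, or a phenyl ring carrying two methyl groups, an amine or a carboxylic acid, would help to tell these apart and show how far the trend from compound 2 to compound 3 extends.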